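A few compounds are considered here, and "the series" means these few. Any claim that something is new, unique, unknown or untested is made for them only; others in the source may bear on it.

Measured so far:
compound 1, `O=C(NCc1cn(Cc2ccc(C(F)(F)F)cc2)nn1)c1ccc([N+](=O)[O-])o1`, 289000 nM
compound 2, `COc1cc(Cn2cc(CNC(=O)c3ccc([N+](=O)[O-])o3)nn2)ccc1O`, 224000 nM

Of the compounds shown here, two share a common core and have been measured in an ADME assay on Vero cells (Chlorocebus sabaeus) for cytotoxicity; a lower number here means a stronger inhibitor, a higher number a weaker inhibitor. Compound 1 gives 289000 nM. Compound 2 gives 224000 nM, the lower of the two numbers, though the gap to compound 1 lies within the usual scatter, so the two cannot be told apart on these data. The unmeasured compound 3, `O=C(NCc1cn(Cc2cccc([N+](=O)[O-])c2)nn1)c1ccc([N+](=O)[O-])o1`, differs from compound 2 in one place: 3-nitrophenyl in place of 4-hydroxy-3-methoxyphenyl on a saturated chain carbon bound to an aromatic nitrogen. Among the measured compounds shown here, no step between measured compounds is known here, so there is nothing to show how a change at this position moves the number in this assay. Given that compounds 1 and 2 sit so close together, the expected step from compound 2 to compound 3 is a 1.1-fold higher number from compound 2 to compound 3 (0.05 log units; within the scatter), no larger than the scatter, in no firm direction. Compound 3 is estimated at 250000 nM, with a range from 100000 nM to 600000 nM.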

Compound 3, half-maximal inhibitory concentration: 326000 nM
Estimate against measurement, compound 3: 1.3-fold (0.12 log units) below; low and high end bracket the measured number.
By their numbers in this assay, from the lowest: compounds 2, 1 and 3 (each within the scatter of the next).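

Exchanging 4-hydroxy-3-methoxyphenyl for 3-nitrophenyl on a saturated chain carbon bound to an aromatic nitrogen gives, in this assay, a 1.5-fold higher number from compound 2 to compound 3 (0.16 log units; within the scatter). Among the compounds shown here, this is the first step that can be read at this position, and it shows that a change which takes away the hydrogen-bond donor and brings in a double bond outside aromatic rings still leaves the number within the scatter. No measurement at hand bears on why this is so.

The compounds shown leave open whether an amine, a carboxylic acid or a longer chain at this position would move the number in this assay beyond the scatter. Equally open, as far as these compounds go, is whether a change elsewhere in the shared core would move it further than any change at this position.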